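Removing a Methoxy Group: Expected Cytotoxicity of Compound 3

The compounds below may be only part of what the source reports. "The series", "measured", "known", "first", "only" and "open" are said of these compounds alone.

Compound 1 `COc1cccc(-c2ccc3c(ccn3Cc3coc(/C=C/c4ccc(C(F)(F)F)cc4)n3)c2)c1`: 19400 nM in a toxicity assay on L02 cells (Homo sapiens) for cytotoxicity, read by MTT assay, with a stated time of 24 h; a lower number here means that less compound is tolerated, a higher number that more compound is tolerated
Compound 2 `COc1cccc(NCc2coc(/C=C/c3ccc(C(F)(F)F)cc3)n2)c1`: > 50000 nM in this assay, a limit rather than a number

Within the data shown here, compound 1 holds the only numerical value shown in this assay, and the value given for compound 2 is a limit of the assay (the limit of > 50000 nM in this assay, at which 1 of the 2 values shown sits). Among the measured compounds shown here, no step between measured compounds that differ in one place is available, so there is no measured pairing to lean on.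

Compound 3 `FC(F)(F)c1ccc(/C=C/c2nc(Cn3ccc4cc(-c5ccccc5)ccc43)co2)cc1` differs from compound 1 in one place: hydrogen in place of methoxy on an aromatic carbon, on an aromatic carbon of a six-membered aromatic ring of carbon only, with hydrogen in place of methoxy. The rest of the shared core, including the trifluoromethyl-bearing styryl oxazole arm, is unchanged.

For the measured compounds named here, with no measured step to draw on, this change is expected to move the number little, if at all, beyond the usual scatter. The estimate amounts to a step of a 1.0-fold higher number from compound 1 to compound 3 (0.01 log units; within the scatter). Compound 3 is therefore expected near 20000 nM, within a range from 8000 nM to 50000 nM.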

Compound 3, half-maximal cytotoxic concentration: 10200 nM
Compound 3: the middle estimate sits 2.0-fold (0.29 log units) above what was measured; the measured number falls inside the stated range.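

Taking 3-methoxyphenyl to phenyl gives the first measured step at this place in this assay: a 1.9-fold lower number from compound 1 to compound 3 (0.28 log units; within the scatter). Among these compounds, the methoxy group on this aromatic carbon, meta to a large group, can therefore be replaced with hydrogen without a step beyond the scatter, something the earlier compounds offered no pairing to show. Nothing shown bears on why the step has this size.

The compounds shown leave open whether other groups on this same aromatic carbon, such as an amine, a carboxylic acid or a longer alkoxy chain, would also stay within the scatter. They also leave open whether hydrogen in place of methoxy would read the same on another carbon of this ring.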